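Hydrazone series, cyano to methyl on the aryl ring

The source may report more compounds than this note shows. Statements on the series, on what has been measured and on what is new or still open speak of the compounds shown alone.

Compound 2 `CC(=O)/C(=N\Nc1ccccc1C#N)N(C)c1cccc(Cl)c1` stands at the assay ceiling: in an assay on isolated protein for binding affinity to corticotropin-releasing factor receptor 1 (Homo sapiens) (a lower number here means a stronger inhibitor, a higher number a weaker inhibitor), compound 2 gives > 10000 nM, a limit rather than a number. Compound 1 `CC(=O)/C(=N\Nc1ccccc1C(F)(F)F)N(C)c1cccc(Cl)c1` likewise gives only a limit in this assay, > 10000 nM. The step that the two limits leave unreadable from compound 1 to compound 2 is therefore not readable, and the limit of > 10000 nM in this assay, at which 2 of the 2 values shown sit, is all the two values show. Compound 3 `CC(=O)/C(=N\Nc1ccccc1C)N(C)c1cccc(Cl)c1` carries methyl in place of cyano on an aromatic carbon. Going by the values given here, no measured step bears readably on this change, so no direction beyond the scatter can be expected, and compound 3 is expected to remain near the same limit, estimated at 8000 nM (range 1500 nM to 30000 nM), an expected step of an at least 1.2-fold lower number from compound 2 to compound 3 (0.09 log units; that floor lies within the scatter).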

Compound 3, inhibition constant: > 10000 nM
Compound 3: only a limit was reported; the forecaster's own chance of this, stated with the estimate: 70%; middle value at least 1.2-fold (0.09 log units) from the limit.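

Going by these compounds alone, compound 3 gives only a limit, as do compound 1 and compound 2, so no step among the three can be read: the limit of > 10000 nM in this assay, at which 3 of the 3 values shown sit.
From the compounds shown here alone, how cyano, methyl and trifluoromethyl on this aromatic carbon compare in this assay stays open.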